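The compounds below may be only part of what the source reports. "The series", "measured", "known", "first", "only" and "open" are said of these compounds alone.

Compound 1 `O=C(CSc1snnc1-c1ccccc1)Nc1ccccc1F` is one member of a small set built on a shared core. In an ADME assay on MT4 cells (Homo sapiens) for cytotoxicity (a higher number here means that more compound is tolerated, a lower number that less compound is tolerated), compound 1 reaches only a limit of the assay, > 361000 nM, rather than a number, namely (the limit of > 361000 nM in this assay, at which 1 of the 3 values shown sits). Two related compounds carry a bromo group: compound 2 `COc1ccc(-c2nnsc2SCC(=O)Nc2ccc(C)cc2Br)cc1` gives 249000 nM in this assay, and compound 3 `COC(=O)c1ccc(NC(=O)CSc2snnc2-c2ccc(OC)cc2)c(Br)c1` gives 195000 nM. Going by the values given here, the single measured step, a 1.3-fold lower number from compound 2 to compound 3 (0.11 log units; within the scatter), changes a part of the molecule unrelated to the halogen. Compound 4 `O=C(CSc1snnc1-c1ccccc1)Nc1ccccc1Br` differs from compound 1 by bromo in place of fluoro on an aromatic carbon. Among the compounds with values here, no measured step covers such a halogen swap, so no direction can be read from the data, and the step of an at least 1.2-fold lower number from compound 1 to compound 4 (0.08 log units; that floor lies within the scatter) is expected to stay within the scatter. Because compound 2 gives 249000 nM and compound 3 gives 195000 nM, compound 4 is estimated at 300000 nM, in the range 150000 nM to 600000 nM.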

Compound 4, half-maximal cytotoxic concentration: > 307000 nM
Compound 4 gave a limit, no number; the forecaster's own chance of this, stated with the estimate: 40%; middle value at least 1.0-fold (0.01 log units) from the limit.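

Compound 1 and compound 4 each reach only a limit of the assay, not a number, and the step between them cannot be read. The compounds shown leave open whether bromo in place of fluoro shifts the read-out in this assay at all.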